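A few compounds are considered here, and "the series" means these few. Any claim that something is new, unique, unknown or untested is made for them only; others in the source may bear on it.

Measured compounds:
- compound 1 `O=C(CCCCCN1CCN(c2noc3ccccc23)CC1)NC1CCCc2ccccc21`: 125 nM
- compound 2 `COc1ccc2oc(N3CCN(CCCCCC(=O)NC4CCCc5ccccc54)CC3)nc2c1`: 704 nM
- compound 3 `COc1ccc(OC)c(N2CCN(CCCCCC(=O)NC3CCCc4ccccc43)CC2)c1`: 70.3 nM

In an assay on HEK293 cells for displacement of a labelled ligand from 5-hydroxytryptamine receptor 7 (Rattus norvegicus) (on this read-out lower numbers stand for stronger inhibition and higher numbers for weaker inhibition), compound 3 shows the lowest number of the three. Its gap to compound 1 is small, a 1.8-fold lower number from compound 1 to compound 3 (0.25 log units; within the scatter), and so the two cannot be ranked; its gap to compound 2 is clear, a 10-fold lower number from compound 2 to compound 3 (1.00 log units; beyond the scatter).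

Compound 4 `CC(=O)c1cccc(N2CCN(CCCCCC(=O)NC3CCCc4ccccc43)CC2)c1` differs from compound 3 in one place: 3-acetylphenyl in place of 2,5-dimethoxyphenyl on an amine nitrogen in a ring. The measured steps that bear on this are those that also exchange the group on the ring amine nitrogen: a 1.8-fold lower number from compound 1 to compound 3 (0.25 log units; within the scatter), which stays within the scatter, and a 10-fold lower number from compound 2 to compound 3 (1.00 log units; beyond the scatter), a modest step. Among the measured compounds shown here, no measured step exchanges a dimethoxyphenyl for an acetylphenyl, so the direction is uncertain; the record shows that such exchanges can move this assay modestly in either sense. Compound 4 is therefore expected to give a 2.3-fold higher number from compound 3 to compound 4 (0.36 log units; beyond the scatter), a modest rise toward the range of compound 1 rather than a large one. The estimate for compound 4 in this assay is 160 nM, with a range from 40 nM to 650 nM.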

Compound 4, inhibition constant: 496 nM
The estimate for compound 4 lay 3.1-fold (0.49 log units) below the measured number; low and high end bracket the measured number.
By their numbers in this assay, from the lowest: compounds 3 and 1 (each within the scatter of the next); then compounds 4 and 2 (each within the scatter of the next).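

In this assay, the exchange on the amine nitrogen of the ring is a clear one, a 7.1-fold higher number from compound 3 to compound 4 (0.85 log units; beyond the scatter), even though the group leaving and the group entering each hold one six-membered aromatic ring of carbon only; that ring alone therefore does not fix the number here, and what it carries matters. The 3-acetylphenyl group also falls behind the group of compound 1, a 4.0-fold higher number from compound 1 to compound 4 (0.60 log units; beyond the scatter), yet it cannot be separated from the 5-methoxy-1,3-benzoxazol-2-yl group, a 1.4-fold lower number from compound 2 to compound 4 (0.15 log units; within the scatter). No measurement at hand explains these differences.

The compounds shown leave open whether the rise in number comes with the arrival of the acetyl group or with the departure of the two methoxy groups. A phenyl ring with a single methoxy group, or an unsubstituted phenyl ring, would help to separate these two readings.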